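The compounds below may be only part of what the source reports. "The series", "measured", "known", "first", "only" and "open" are said of these compounds alone.

Measured compounds, all in a toxicity assay on MDCK cells (Canis lupus familiaris) for cytotoxicity, read by CCK-8 assay, with a stated time of 48 h; a higher number here means that more compound is tolerated, a lower number that less compound is tolerated:
- compound 1 `CC(C)(C)c1ccc(C(=O)NNc2c(Br)cccc2Br)cc1`: > 100000 nM
- compound 2 `CCOc1ccc(C(=O)NNc2c(C)cccc2C)cc1`: > 100000 nM
- compound 3 `CCOc1ccc(C(=O)NNc2ccccc2Br)cc1`: > 100000 nM

Compound 1 gives > 100000 nM, which is a limit of the assay and not a number. Compound 2 gives > 100000 nM, which is also a limit. Compound 3 gives > 100000 nM, again a limit. Compound 1 therefore has no exact reading and stands with the other two at the limit of > 100000 nM in this assay, at which 3 of the 3 values shown sit.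

The next compound to be tested is compound 4 `CN(C)c1ccc(C(=O)NNc2c(Br)cccc2Br)cc1`. It keeps the core of compound 1 but carries dimethylamino in place of tert-butyl on an aromatic carbon, para to a large group: dimethylamino in place of tert-butyl on an aromatic carbon.

Within the data shown here, no two measured compounds differ in just one place, so no measured step can serve as a guide to the size of this change. The expectation rests on the limit of compound 1, > 100000 nM, and on the same kind of limit for compound 2 and compound 3. In this assay, no step beyond the usual scatter is expected, and compound 4 will probably also reach the limit. The estimated change is a number no higher from compound 1 to compound 4 (the limit leaves the size open). For compound 4 the expected value is 100000 nM, with an estimated range from 40000 nM to 200000 nM.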

Compound 4, half-maximal cytotoxic concentration: > 100000 nM
Compound 4: no number, only a limit (the forecaster's own chance of this, stated with the estimate: 80%); the middle value sits exactly at the limit.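

Among these compounds, compound 1 and compound 4 both stand at a limit of the assay and not at a number, so no step between them can be read in this assay: the limit of > 100000 nM in this assay, at which 4 of the 4 values shown sit. The compounds shown leave open at what concentration any of them harms these cells, and whether swapping tert-butyl for dimethylamino changes that concentration at all.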